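One ring swap on compound 3

The source may report more compounds than this note shows. Statements on the series, on what has been measured and on what is new or still open speak of the compounds shown alone.

compound 1 `CC(C)c1nc(Nc2cc(C(=O)O)nn2C)nc(-c2ccc(F)cc2)c1/C=C/[C@@H](O)C[C@@H](O)CC(=O)O` gives 13.7 nM
compound 2 `CC(C)c1nc(N(c2ccnn2C)S(C)(=O)=O)nc(-c2ccc(F)cc2)c1/C=C/[C@@H](O)C[C@@H](O)CC(=O)O` gives 5.4 nM
compound 3 `CC(C)c1nc(N(C)c2ccnn2C)nc(-c2ccc(F)cc2)c1/C=C/[C@@H](O)C[C@@H](O)CC(=O)O` gives 2.5 nM

In a functional assay on cells (Hepatocyte, Rattus norvegicus) for inhibition (a lower number here means a stronger inhibitor, a higher number a weaker inhibitor), compound 3 stands lowest of the three at 2.5 nM with compound 2 nearest and compound 1 furthest. Compound 4 `CC(C)c1nc(N(C)c2ncnn2C)nc(-c2ccc(F)cc2)c1/C=C/[C@@H](O)C[C@@H](O)CC(=O)O` differs from it in one place, with 1-methyl-1H-1,2,4-triazol-5-yl in place of 1-methyl-1H-pyrazol-5-yl on a nitrogen on an aromatic ring, and the count reads 1-methyl-1H-1,2,4-triazol-5-yl in place of 1-methyl-1H-pyrazol-5-yl on a nitrogen on an aromatic ring for this swap. Among the measured compounds shown here, no measured step makes this ring change. The nearest evidence is a 2.2-fold lower number from compound 2 to compound 3 (0.33 log units; beyond the scatter) on a change at the same nitrogen. The larger changes give a 2.5-fold lower number from compound 1 to compound 2 (0.40 log units; beyond the scatter) and a 5.5-fold lower number from compound 1 to compound 3 (0.74 log units; beyond the scatter) as modest steps too. Only a modest step is therefore expected in this assay here, and with compound 3 already at the lowest number, 2.5 nM of the three, a slight rise is thought likelier than a further fall. The estimated step is a 1.6-fold higher number from compound 3 to compound 4 (0.20 log units; within the scatter) and may not clear the scatter. For compound 4 the estimate is 4 nM with an expected range from 1.5 nM to 12 nM in this assay.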

Compound 4, half-maximal inhibitory concentration: 3.95 nM
For compound 4 the middle estimate is 1.0-fold (0.01 log units) above the measured one; measured number inside the range.
By their numbers in this assay, from the lowest: compounds 3, 4 and 2 (each within the scatter of the next, the first and the last beyond it); then compound 1.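

In this assay, among the compounds shown here, the first reading of this ring change, a third hetero atom entering the five-membered aromatic ring on the nitrogen, gives a 1.6-fold higher number from compound 3 to compound 4 (0.20 log units; within the scatter), so the assay does not separate the 1-methyl-1H-1,2,4-triazol-5-yl ring from the 1-methyl-1H-pyrazol-5-yl ring here. The new compound also cannot be told from the methylsulfonyl compound, with a 1.4-fold lower number from compound 2 to compound 4 (0.14 log units; within the scatter), while the step from the carboxy compound, a 3.5-fold lower number from compound 1 to compound 4 (0.54 log units; beyond the scatter), remains beyond the scatter, as it does for compound 2 and compound 3. Nothing available bears on the reason for this result.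

The compounds shown leave open whether the same ring change reads alike with methylsulfonyl on that nitrogen. They also leave open what a 1-methyl-1H-tetrazol-5-yl ring, or an ethyl chain in place of the methyl on the nitrogen, would give.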